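The source may report more compounds than this note shows. Statements on the series, on what has been measured and on what is new or still open speak of the compounds shown alone.

Within the data shown here, compound 1 `C/C(=N\NC(=O)/C(C#N)=C/c1ccccc1)c1c(O)c2ccc(O)cc2oc1=O` is, on the numbers measured so far, the compound with the highest value: in a functional assay on A549 cells (Homo sapiens) for cytotoxicity, read by MTT assay, with a stated time of 24 h (a higher number here means a weaker inhibitor, a lower number a stronger inhibitor), compound 1 gives 14800 nM. Among the measured compounds shown here, its nearest neighbour is compound 2 `COc1ccc(/C=C(\C#N)C(=O)N/N=C(\C)c2c(O)c3ccc(O)cc3oc2=O)cc1`, which in this assay gives 8150 nM, and the only measured step, a 1.8-fold lower number from compound 1 to compound 2 (0.26 log units; within the scatter), stays inside the scatter of this kind of test.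

Compound 3 `C/C(=N\NC(=O)/C(C#N)=C/c1cccc(Br)c1)c1c(O)c2ccc(O)cc2oc1=O` is the next structure to consider. It differs from compound 1 by one change: bromo in place of hydrogen on an aromatic carbon. For the measured compounds named here, no measured step involves a bromo group, so the only guidance is the one step, from compound 1 to compound 2, where a single substituent on the same six-membered ring left the number essentially unchanged. A similar outcome is therefore expected here: the step of a 1.2-fold lower number from compound 1 to compound 3 (0.09 log units; within the scatter) is estimated to remain within the scatter. Compound 3 is expected to give 12000 nM in this assay, with a likely range from 5000 nM to 30000 nM.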

Compound 3, half-maximal inhibitory concentration: 22200 nM
The estimate for compound 3 lay 1.9-fold (0.27 log units) below the measured number, within the range that was stated.
By their numbers in this assay, from the lowest: compounds 2, 1 and 3 (each within the scatter of the next, the first and the last beyond it).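

In this assay, adding bromo to the phenyl ring, meta to a large group, gives a 1.5-fold higher number from compound 1 to compound 3 (0.18 log units; within the scatter), so a bromo group at this place cannot be told apart from hydrogen. The new information lies in the comparison of the two substituted compounds: with 3-bromophenyl in place of 4-methoxyphenyl there is a 2.7-fold higher number from compound 2 to compound 3 (0.44 log units; beyond the scatter), a modest step, and the first one here beyond the scatter, even though neither compound stands clearly apart from compound 1. No available evidence accounts for this gap.

The compounds shown leave open how much of that gap comes from the group itself and how much from where it sits on the ring, since bromo and methoxy appear at different places. They also leave open how an amine or a carboxylic acid on this ring would read in this test.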